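The compounds below may be only part of what the source reports. "The series", "measured", "known", "first", "only" and "open" are said of these compounds alone.

Measured in a functional assay on A-375 cells (Homo sapiens) for cytotoxicity, read by MTT assay, with a stated time of 72 h; on this read-out higher numbers stand for weaker inhibition and lower numbers for stronger inhibition:
- compound 1 `O=C1c2c[n+]([O-])c3ccccc3c2C(=O)c2c1c1ccccc1n2CCCCn1ccnc1`: 350 nM
- compound 2 `O=C1c2c[n+]([O-])c3ccccc3c2C(=O)c2c1c1ccccc1n2Cc1cn(CC(O)CO)nn1`: 440 nM
- compound 3 `CN1CCN(CCCCn2c3c(c4ccccc42)C(=O)c2c[n+]([O-])c4ccccc4c2C3=O)CC1`: 30 nM

Compound 3 has the lowest number of the three, which makes it the strongest inhibitor in this small set. There is a 12-fold lower number from compound 1 to compound 3 (1.07 log units; beyond the scatter), and there is a 15-fold lower number from compound 2 to compound 3 (1.17 log units; beyond the scatter).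

Compound 4 `O=C1c2c[n+]([O-])c3ccccc3c2C(=O)c2c1c1ccccc1n2CCCCN1CCCCC1` keeps the shared core of compound 3. The difference is piperidin-1-yl in place of 4-methylpiperazin-1-yl on a saturated chain carbon, four bonds along the chain from an aromatic nitrogen, on a saturated chain carbon, four bonds along the chain from an aromatic nitrogen.

The most relevant evidence comes from the same place, where 4-methylpiperazin-1-yl replaced 1H-imidazol-1-yl: a 12-fold lower number from compound 1 to compound 3 (1.07 log units; beyond the scatter). That large step shows that the group here can matter in this assay. Going by the values given here, no measured step swaps 4-methylpiperazin-1-yl for piperidin-1-yl, however, and both contain one six-membered non-aromatic ring. A modest rise in the number is therefore expected, much smaller than that step. The expected step is a 2.0-fold higher number from compound 3 to compound 4 (0.30 log units; within the scatter). For compound 4 the estimate is 60 nM, with an expected range of 20 nM to 200 nM.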

Compound 4, half-maximal inhibitory concentration: 190 nM
For compound 4 the middle estimate is 3.2-fold (0.50 log units) below the measured one; the range from low to high includes it.
By their numbers in this assay, from the lowest: compound 3; then compounds 4, 1 and 2 (each within the scatter of the next, the first and the last beyond it).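

In this assay, two six-membered non-aromatic rings are not interchangeable at this place: piperidin-1-yl in place of 4-methylpiperazin-1-yl gives a 6.3-fold higher number from compound 3 to compound 4 (0.80 log units; beyond the scatter), so the low number of compound 3 depends on more than having such a ring on the chain. Set against the other side chains, 3-(piperidin-1-yl)propyl in place of 1-(2,3-dihydroxypropyl)-1H-1,2,3-triazol-4-yl gives a 2.3-fold lower number from compound 2 to compound 4 (0.36 log units; beyond the scatter), while piperidin-1-yl in place of 1H-imidazol-1-yl gives only a 1.8-fold lower number from compound 1 to compound 4 (0.27 log units; within the scatter). Nothing available explains these differences.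

The compounds shown leave open whether the effect rests on the second ring nitrogen or on the methyl attached to it. Unsubstituted piperazin-1-yl and morpholin-4-yl on the same chain would help separate those two parts.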